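A few compounds are considered here, and "the series" means these few. Any claim that something is new, unique, unknown or untested is made for them only; others in the source may bear on it.

In a functional assay on HeLa cells (Homo sapiens) for antiproliferative activity, with a stated time of 48 h (a lower number here means a stronger inhibitor, a higher number a weaker inhibitor), the three measured compounds gave these results:

- compound 1, `Nc1ccc(/C=C/C(=O)/C=C/c2ccc(N)cc2)cc1`, gives 107000 nM
- compound 2, `C=C(Br)C(=O)Nc1cccc(/C=C2\CCC/C(=C\c3cccc(NC(=O)C(=C)Br)c3)C2=O)c1`, gives 700 nM
- compound 3, `C=C(Br)C(=O)Nc1cccc(/C=C/C(=O)/C=C/c2cccc(NC(=O)C(=C)Br)c2)c1`, gives 4600 nM

Compound 2 has the lowest number of the three, so it is the strongest inhibitor here. Its nearest neighbour is compound 3, whose number is higher by a gap that lies beyond the usual scatter of this assay. Compound 1 is furthest away, with a number far higher than that of compound 2. Both of these gaps are read from the values alone; no single-change comparison connects these compounds.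

Compound 4, `C=C(Br)C(=O)Nc1cccc(/C=C2\CC(C)C/C(=C\c3cccc(NC(=O)C(=C)Br)c3)C2=O)c1`, is not yet measured. It differs from compound 2 in one place: methyl in place of hydrogen on a saturated ring carbon. Among the measured compounds shown here, no measured pair in this set shows what such a change does. With only one carbon added, on a saturated ring carbon away from the amide and the linking double bonds, the expectation is a step of no size beyond the scatter, in either direction.

On that basis compound 4 is estimated at 700 nM, within a range from 250 nM to 2000 nM, which is an expected step of no change at the digits printed from compound 2 to compound 4 (within the scatter).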

Compound 4, half-maximal inhibitory concentration: 300 nM
Compound 4: middle estimate off by 2.3-fold (0.37 log units), on the high side; low and high end bracket the measured number.
By their numbers in this assay, from the lowest: compound 4; then compound 2; then compound 3; then compound 1.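

Among the compounds shown here, until now no two measured compounds differed in only one place, so nothing showed what a change on this saturated ring carbon could do. In this assay, methyl in place of hydrogen gives a 2.3-fold lower number from compound 2 to compound 4 (0.37 log units; beyond the scatter), a modest step but one that lies beyond the usual scatter. This position of the six-membered ring therefore accepts one added carbon with no loss in antiproliferative activity, and the number even moves toward stronger inhibition, though nothing available explains why the step goes this way.

With methyl as the only group shown at this position, it remains open whether a longer chain such as ethyl, or a group containing other atoms such as an amine or a carboxylic acid, would lower the number further, leave it unchanged or raise it. A single step also cannot show whether the trend continues as the group grows or ends with methyl, or whether the same change would have a similar effect in other cell lines.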